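The source may report more compounds than this note shows. Statements on the series, on what has been measured and on what is new or still open speak of the compounds shown alone.

Measured so far in a functional assay on CHO cells for agonist activity at Free fatty acid receptor 1 (Homo sapiens), read by FLIPR and calcium flux, tested at 1 uM; a higher number here means that more compound is needed for the effect, a lower number that less compound is needed:
compound 1 `O=C(O)CCc1ccc(NC(=O)c2nnc(COc3ccc(F)cc3)s2)cc1` – 5390 nM
compound 2 `Cc1ccc(OCc2nnc(C(=O)Nc3ccc(CCC(=O)O)cc3)s2)cc1C` – 1130 nM
compound 3 `CCc1ccc(OCc2nnc(C(=O)Nc3ccc(CCC(=O)O)cc3)s2)cc1` – 1170 nM

Compound 2 has the lowest number of the three, but compound 3 sits within the scatter of it, a 1.0-fold higher number from compound 2 to compound 3 (0.02 log units; within the scatter); only compound 1 stands clearly apart, a 4.8-fold lower number from compound 1 to compound 2 (0.68 log units; beyond the scatter). Compound 4 `COc1ccc(OCc2nnc(C(=O)Nc3ccc(CCC(=O)O)cc3)s2)cc1` has not been measured; it differs from compound 2 by 4-methoxyphenyl in place of 3,4-dimethylphenyl on an oxygen on a saturated carbon. Among the compounds with values here, no measured step covers a methoxy group. Within the data shown here, the steps that bear on the change are the one from compound 1 to compound 2 and the one from compound 2 to compound 3: the alkyl-bearing phenoxy groups of compound 2 and compound 3 are interchangeable, while the fluoro of compound 1 gives a clearly higher number. The methoxy case is expected to fall between these outcomes, so a modest rise in this assay is estimated, a 2.1-fold higher number from compound 2 to compound 4 (0.33 log units; beyond the scatter). For compound 4 the expected value is 2400 nM, with a range of 1000 nM to 6000 nM.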

Compound 4, half-maximal effective concentration: 2430 nM
The estimate for compound 4 lay 1.0-fold (0.01 log units) below the measured number; the measured number falls inside the stated range.
By their numbers in this assay, from the lowest: compounds 2 and 3 (each within the scatter of the next); then compound 4; then compound 1.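

Methoxy in this place does not match the alkyl groups: the 4-methoxyphenyl group gives a higher number than the 3,4-dimethylphenyl group (a 2.2-fold higher number from compound 2 to compound 4 (0.33 log units; beyond the scatter)) and than the ethyl of compound 3 (a 2.1-fold higher number from compound 3 to compound 4 (0.32 log units; beyond the scatter)). It still gives a lower number than fluoro (a 2.2-fold lower number from compound 1 to compound 4 (0.35 log units; beyond the scatter)), so the three kinds of group on this ring now fall into separate levels, with compound 2 and compound 3 together at the lowest.

As far as these compounds go, a longer ether such as propoxy, or a chlorine or trifluoromethyl on this ring, remains open. Nothing available accounts for this order.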